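The source may report more compounds than this note shows. Statements on the series, on what has been measured and on what is new or still open speak of the compounds shown alone.

Working notes on the series. Compound 3 `CCC(C)(C)Cc1c[nH]c(CCc2ccc(-n3cncn3)cc2)n1` is one of three close analogues built on a shared core; the other two are compound 1 `CCC(C)(C)Cc1c[nH]c(CCc2ccc(-c3ccncc3)cc2)n1` and compound 2 `CCC(C)(C)Cc1c[nH]c(CCc2ccc(-n3ncnn3)cc2)n1`. In a functional assay on HEK293 cells for agonist activity at Bombesin receptor subtype-3 (Mus musculus), read by luminescence and calcium flux, with a stated time of 10 min (on this read-out higher numbers stand for an effect only at larger amounts of compound and lower numbers for an effect already at smaller amounts), compound 3 gives 121 nM, the highest of the three numbers, yet within the scatter of both companions: in this assay compound 1 gives 103 nM and compound 2 gives 99 nM. The steps among them are all small: a 1.0-fold lower number from compound 1 to compound 2 (0.02 log units; within the scatter), a 1.2-fold higher number from compound 1 to compound 3 (0.07 log units; within the scatter) and a 1.2-fold higher number from compound 2 to compound 3 (0.09 log units; within the scatter). The next compound, compound 4 `CCC(C)(C)Cc1c[nH]c(CCc2ccc(-c3cccnc3)cc2)n1`, differs from compound 3 in one place: pyridin-3-yl in place of 1H-1,2,4-triazol-1-yl on an aromatic carbon. The step that bears on it most directly is the earlier exchange of a pyridinyl for the triazolyl on the same aromatic carbon, a 1.2-fold higher number from compound 1 to compound 3 (0.07 log units; within the scatter), which stayed within the scatter; the exchange between the two five-membered groups, a 1.2-fold higher number from compound 2 to compound 3 (0.09 log units; within the scatter), did the same. Within the data shown here, nothing measured so far separates the five-membered from the six-membered groups on this carbon beyond the usual spread, and no pyridin-3-yl analogue has been run yet. Compound 4 is therefore expected to stay in the same range, with a step of a 1.2-fold lower number from compound 3 to compound 4 (0.06 log units; within the scatter) that amounts to no change beyond the scatter. The estimate for compound 4 in this assay is 105 nM, with a range from 50 nM to 220 nM.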

Compound 4, half-maximal effective concentration: 97 nM
The estimate for compound 4 lay 1.1-fold (0.03 log units) above the measured number; the range from low to high includes it.
By their numbers in this assay, from the lowest: compounds 4, 2, 1 and 3 (each within the scatter of the next).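

Among these compounds, the exchange of pyridin-4-yl for pyridin-3-yl in this assay is the first comparison of two pyridine isomers on this aromatic carbon, para to a large group, and it gives a 1.1-fold lower number from compound 1 to compound 4 (0.03 log units; within the scatter), so the place of the ring nitrogen within the six-membered group does not register here. Pyridin-3-yl also gives a 1.2-fold lower number from compound 3 to compound 4 (0.10 log units; within the scatter) and a 1.0-fold lower number from compound 2 to compound 4 (0.01 log units; within the scatter), which adds a direct comparison of this isomer with each five-membered group. Across these steps, the series now tolerates either pyridine isomer or either five-membered group on this carbon with no difference beyond the scatter, even though the exchange of 1H-1,2,4-triazol-1-yl for pyridin-3-yl goes from three ring hetero atoms to one and from three hydrogen-bond acceptors to one.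

As far as these compounds go, all four groups are aromatic rings, so it remains open whether a carboxylic acid, an aminomethyl group, a plain phenyl ring or a small group such as methyl on this carbon would stay within this range. The data at hand give no explanation for the absence of a difference among these four groups.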